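The compounds below may be only part of what the source reports. "The series", "measured", "known", "first", "only" and "open" are said of these compounds alone.

Three compounds have been run in an assay on CHO cells for displacement of a labelled ligand from transient receptor potential cation channel subfamily V member 1 (Rattus norvegicus); a higher number here means a weaker inhibitor, a lower number a stronger inhibitor. Compound 1 `COc1cc(CNC(=S)NCC(COC(=O)C(C)(C)C)Cc2ccc(C)c(C)c2)c(Cl)cc1O` gives 24.2 nM in this assay. Compound 2 `COc1cc(CNC(=S)NC(CCc2ccc(C(C)(C)C)cc2)COC(=O)C(C)(C)C)c(Br)cc1O` gives 75 nM. Compound 3 `COc1cc(CNC(=S)NCc2ccc(C(C)(C)C)cc2)c(Cl)cc1O` gives 36.9 nM, which is the second highest of the three numbers; the gap between compound 3 and compound 1 lies within the usual scatter of repeated measurements, so no order between the two can be claimed, whereas the gap between compound 3 and compound 2 is beyond that scatter, with compound 2 showing the higher number and hence the weaker inhibition.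

Compound 4 `COc1cc(CNC(=S)NCc2ccc(C(C)(C)C)cc2)c(I)cc1O` is not yet measured. It differs from compound 3 in one place: iodo in place of chloro on an aromatic carbon. Within the data shown here, no pair of measured compounds differs in exactly this way, so there is no measured step to lean on. Compound 2 does carry a bromo group on the corresponding ring, but it also differs from compound 3 in the rest of the molecule, so its value says nothing direct about the halogen alone.

For compound 4 the expectation is a step of a 1.2-fold lower number from compound 3 to compound 4 (0.09 log units; within the scatter) from compound 3, that is, no change beyond the scatter. Compound 4 is therefore estimated at 30 nM, with a range from 10 nM to 90 nM.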

Compound 4, inhibition constant: 130 nM
Compound 4: the middle estimate sits 4.3-fold (0.64 log units) below what was measured; the whole stated range lies below it.
By their numbers in this assay, from the lowest: compounds 1 and 3 (each within the scatter of the next); then compounds 2 and 4 (each within the scatter of the next).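

At this ring carbon, ortho to a large group, meta to a hydroxy group and para to a methoxy group, the identity of the halogen matters in this assay, with iodo in place of chloro giving a 3.5-fold higher number from compound 3 to compound 4 (0.55 log units; beyond the scatter) and thus a change beyond the scatter. Compound 2 also carries a halogen on the corresponding ring, but it differs from compound 3 in the rest of the molecule as well, so this pair is the only one shown that isolates a halogen change with everything else held constant. Nothing measured here bears on why the number rises with this change.

On these data alone, it remains open where a bromo group would fall on the otherwise unchanged structure of compound 3, and what a fluoro group, a methyl group, a trifluoromethyl group or plain hydrogen would give at this carbon. As far as these compounds go, it is also open whether the same change from chloro to iodo would give a similar step in a compound with the ester-bearing chain of compound 1 rather than the simple benzyl group of compound 3.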